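This account rests on a few compounds, and the source may have more. Where it says the series, first, only, none or still open, it means among the compounds named here.

Compound 1 `N#Cc1cc(F)cc(C(=O)Nc2nccs2)c1` carries only hydrogen on the aromatic carbon of its five-membered ring. In an in vitro functional assay on HEK293-A cells for antagonist activity at metabotropic glutamate receptor 5 (Rattus norvegicus), read by calcium flux (a higher number here means a weaker inhibitor, a lower number a stronger inhibitor), compound 1 gives > 10000 nM, which is a limit of the assay rather than a number. Compound 3 `N#Cc1cc(F)cc(C(=O)Nc2nc(C3CC3)cs2)c1` gives 900 nM in this assay, and the change is an at least 11-fold lower number from compound 1 to compound 3 (1.04 log units; beyond the scatter), with the starting point being (the limit of > 10000 nM in this assay, at which 1 of the 3 values shown sits). Compound 2 `Cc1nc(NC(=O)c2cc(F)cc(C#N)c2)sc1C` gives 594 nM; compound 3 and compound 2 lie within the scatter of each other, so no order between them can be claimed. Compound 4 `CC(C)(C)c1csc(NC(=O)c2cc(F)cc(C#N)c2)n1` differs from compound 3 by tert-butyl in place of cyclopropyl on an aromatic carbon. Among the measured compounds shown here, no measured step exchanges one carbon group for another, so the step is expected to be small, a 1.3-fold higher number from compound 3 to compound 4 (0.12 log units; within the scatter). Compound 4 is therefore estimated at 1200 nM, between 400 nM and 4000 nM.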

Compound 4, half-maximal inhibitory concentration: > 10000 nM
Compound 4 gave a limit, no number (the forecaster's own chance of this, stated with the estimate: 10%); at least 8.3-fold (0.92 log units) between middle value and limit.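

On this aromatic carbon, next to the ring nitrogen, one carbon group cannot simply stand in for another: tert-butyl in place of cyclopropyl gives an at least 11-fold higher number from compound 3 to compound 4 (1.04 log units; beyond the scatter) in this assay. A carbon group here therefore does not by itself bring the gain seen with cyclopropyl. Compound 4 sits at a limit of the assay, as compound 1 does, so the step between them cannot be read: the limit of > 10000 nM in this assay, at which 2 of the 4 values shown sit.

The compounds shown leave open whether the ring of cyclopropyl is what counts at this position. They also do not tell how isopropyl, cyclobutyl or an amine on this carbon would behave.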